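The source may hold more compounds than are shown below. What is called first, only, known or untested is meant among the compounds shown, and "the series" means these compounds.

Compound 1 `CC(C)C(Cc1ncc[nH]1)c1ccc(-c2ccc3cccc(F)c3c2)[nH]c1=O` stands highest of the three numbers in a functional assay on CHO cells for antagonist activity at prostaglandin E2 receptor EP3 subtype (Homo sapiens), read by cAMP accumulation (a lower number here means a stronger inhibitor, a higher number a weaker inhibitor), where compound 1 gives 76 nM. Compound 2 `CC(C)C(c1ccc(-c2ccc3cccc(F)c3c2)[nH]c1=O)N1CCN/C1=N\C#N` gives 38 nM, a step of a 2.0-fold lower number from compound 1 to compound 2 (0.30 log units; within the scatter). Compound 3 `CC(C)C(/C=C1/CCNC1=O)c1ccc(-c2ccc3cccc(F)c3c2)[nH]c1=O` gives 8.1 nM, a step of a 9.4-fold lower number from compound 1 to compound 3 (0.97 log units; beyond the scatter). Compound 4 `CC(C)C(/C=C1\CCNC1=O)c1ccc(-c2ccc3cccc(F)c3c2)[nH]c1=O` differs from compound 1 on a saturated chain carbon bound to an aromatic carbon and a saturated chain carbon: a group of 7 heavy atoms (5 carbon, 1 nitrogen, 1 oxygen; one five-membered non-aromatic ring with 1 hetero atom) in place of a group of 6 heavy atoms (4 carbon, 2 nitrogen; one five-membered aromatic ring with 2 hetero atoms), on a saturated chain carbon bound to an aromatic carbon and a saturated chain carbon. The entering group carries the same count of atoms and the same five-membered non-aromatic ring as that of compound 3, with a different arrangement about one of its two double bonds outside aromatic rings. The step that bears on it is a 9.4-fold lower number from compound 1 to compound 3 (0.97 log units; beyond the scatter), modest and beyond the scatter, so a step in the same direction, perhaps smaller, is expected: a 5.1-fold lower number from compound 1 to compound 4 (0.70 log units; beyond the scatter). Compound 4 is therefore estimated at 15 nM, between 5 nM and 45 nM.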

Compound 4, half-maximal inhibitory concentration: 8.7 nM
The estimate for compound 4 lay 1.7-fold (0.24 log units) above the measured number, and the stated range covers the measured number.
By their numbers in this assay, from the lowest: compounds 3 and 4 (each within the scatter of the next); then compounds 2 and 1 (each within the scatter of the next).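

Reversing the double bond in the entering group gives a 1.1-fold higher number from compound 3 to compound 4 (0.03 log units; within the scatter) in this assay, so at this position the number does not depend on how that bond is drawn. The gain holds for the second geometry too, with an 8.7-fold lower number from compound 1 to compound 4 (0.94 log units; beyond the scatter) and a 4.4-fold lower number from compound 2 to compound 4 (0.64 log units; beyond the scatter). This reading of the geometry carries a caveat: the fact that one of compounds 3 and 4 is drawn with a defined configuration and the other without, at the place where they differ.

The compounds shown leave open whether the double bond itself is needed, since no saturated chain links the ring to this carbon. They also leave open whether a six-membered ring, or a methyl group on the ring nitrogen, would serve as well.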